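The source may report more compounds than this note shows. Statements on the series, on what has been measured and on what is new or still open speak of the compounds shown alone.

Series notes, values measured so far in a functional assay on MCF7 cells (Homo sapiens) for cytotoxicity, read by WST assay, with a stated time of 72 h (a higher number here means a weaker inhibitor, a lower number a stronger inhibitor), for the compounds below
- compound 1 `CCOc1ccc(C2(c3ccc(O)cc3)C(=O)Nc3c2ccc(F)c3F)cc1` gives 11 nM
- compound 2 `CCCCCC1(c2ccc(O)cc2)C(=O)Nc2c1ccc(F)c2F` gives 96 nM
- compound 3 `O=C1Nc2ccccc2C1(c1ccc(O)cc1)c1ccc(F)cc1` gives 28 nM

Compound 3 at 28 nM stands in the middle of these three numbers, with compound 1 lower and compound 2 higher, both gaps beyond the usual scatter. Next in view is compound 4 `O=C1Nc2ccccc2C1(c1ccc(O)cc1)C1CCCCCC1` with cycloheptyl in place of 4-fluorophenyl on a saturated ring carbon. Going by the values given here, one measured step bears on this change. Pentyl in place of 4-ethoxyphenyl on a saturated ring carbon gives an 8.7-fold higher number from compound 1 to compound 2 (0.94 log units; beyond the scatter) and counts as modest. That step also replaces a substituted phenyl with a saturated carbon group, but it sits on the core of compound 1, and its entering group is an open chain and not a ring, so it is only a rough guide. Going by compound 2 and its step of an 8.7-fold higher number from compound 1 to compound 2 (0.94 log units; beyond the scatter) a higher number is expected in this assay here too, of similar or somewhat smaller size. The step expected is a 3.2-fold higher number from compound 3 to compound 4 (0.51 log units; beyond the scatter) with wide uncertainty. The estimate for compound 4 is 90 nM with an expected range from 25 nM to 320 nM on repeat measurement.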

Compound 4, half-maximal inhibitory concentration: 247 nM
For compound 4 the middle estimate is 2.7-fold (0.44 log units) below the measured one; the range from low to high includes it.
By their numbers in this assay, from the lowest: compound 1; then compound 3; then compound 2; then compound 4.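

In this assay the number at this saturated ring carbon rises with a ring entering as well as with an open chain: cycloheptyl in place of 4-fluorophenyl gives an 8.8-fold higher number from compound 3 to compound 4 (0.95 log units; beyond the scatter) and this stands alongside an 8.7-fold higher number from compound 1 to compound 2 (0.94 log units; beyond the scatter) for pentyl in place of 4-ethoxyphenyl on the core of compound 1. Both listed steps on this carbon replace a substituted phenyl with a saturated carbon group, both go the same way, and neither goes against the other, though they sit on different cores. In the new step the heavy-atom count of the leaving and entering groups is the same, and what changes is an aromatic ring carrying fluorine for a larger non-aromatic carbon ring, but nothing available explains the rise.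

Open, going by these compounds, is whether the aromatic ring itself or its fluorine matters, which unsubstituted phenyl or pyridyl at this carbon would address. Also open, on these data alone, is how smaller saturated rings such as cyclopentyl or cyclohexyl, or a nitrogen-containing ring such as piperidinyl, would read against cycloheptyl on the shared core.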